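This account rests on a few compounds, and the source may have more. Where it says the series, first, only, none or still open, it means among the compounds named here.

Working notes on the series. Compound 1 `N/C(=N\NC(=S)N1CCCCC1)c1ccccn1`, compound 3 `N/C(=N\NC(=S)N1CCCC1)c1ccccn1` and compound 2 `Cc1cccc(/C(N)=N/NC(=S)N2CCCC2)n1` have been measured; compound 4 `Cc1ccnc(/C(N)=N/NC(=S)N2CCCCC2)c1` has not. In a functional assay on HeLa cells (Homo sapiens) for cytotoxicity, read by MTT assay, with a stated time of 72 h, tested at 10 uM (a higher number here means more inhibition of growth at the concentration tested, a lower number less inhibition of growth), compound 1 gives 55.7%, the lowest of the three numbers. In this assay compound 3 gives 63.5% and compound 2 gives 79.2%.

Compound 1 and compound 3 differ in the core: piperidin-1-yl in place of pyrrolidin-1-yl on a thiocarbonyl carbon. The step of a number 7.8 percentage points higher from compound 1 to compound 3 (within the scatter) lies within the scatter.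

One structural change occurs twice. From compound 3 to compound 2 it is methyl in place of hydrogen on an aromatic carbon, and it gives the step of a number 15.7 percentage points higher from compound 3 to compound 2 (beyond the scatter). From compound 1 to compound 4 it is methyl in place of hydrogen on an aromatic carbon. The places are not the same: in compound 2 the methyl sits next to the ring nitrogen, meta to a large group; in compound 4 it sits meta to a large group, opposite the ring nitrogen. The change is therefore the same kind of change, not the same.

For compound 4 a step of a number 8.3 percentage points higher from compound 1 to compound 4 (within the scatter) in this assay is expected because a number 15.7 percentage points higher from compound 3 to compound 2 (beyond the scatter) from compound 3 to compound 2 follows the same kind of change. The expected step is kept smaller than that one: in compound 4 the methyl sits at a different place, meta to a large group and opposite the ring nitrogen. Compound 4 is estimated at 64%, between 50% and 78%.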

Compound 4, percent growth inhibition at one concentration: 62.1%
Compound 4: middle estimate off by 1.9 percentage points, on the high side; measured number inside the range.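

In this assay, methyl in place of hydrogen on an aromatic carbon gives a number 6.4 percentage points higher from compound 1 to compound 4 (within the scatter), so on the core of compound 1 the change cannot be told from the scatter of repeated measurements. Set beside the step on the other core, the two results do not differ by more than such steps scatter, and the series gives no sign so far that the change behaves differently from one core to the other: the same change on two cores in this assay, a number 15.7 percentage points higher (beyond the scatter) from compound 3 to compound 2 and a number 6.4 percentage points higher (within the scatter) from compound 1 to compound 4, 9.3 percentage points apart, within the scatter of two such steps

This does not show that the change carries over unchanged, since it rests on a single pair of steps, and the methyl differs in place as well as in core, so the two influences cannot be separated.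

The compounds shown leave open what each methyl place gives on the other core, which would separate place from core. They also leave open what a larger group at the place opposite the ring nitrogen, such as methoxy or a carboxylic acid, would give on either core.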